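The compounds below may be only part of what the source reports. "The series", "measured", "known", "first", "only" and "open" are said of these compounds alone.

Of the compounds shown here, three built on one shared core have been tested in a functional assay on MGC-803 cells (Homo sapiens) for antiproliferative activity, read by CCK-8 assay, with a stated time of 72 h, tested at 2 uM; a lower number here means a weaker effect, a higher number a stronger effect of the compound at the concentration tested. Compound 1 `CCN(Cc1ccncc1)C(=S)SCc1ccc(C(=O)Nc2ccccc2N)cc1` carries an ethyl((pyridin-4-yl)methyl)amino group on its thiocarbonyl carbon, and in this assay compound 1 gives 71.6%. Compound 2 `COc1ccc(N2CCN(C(=S)SCc3ccc(C(=O)Nc4ccccc4N)cc3)CC2)cc1` instead has the amine nitrogen held in a ring, and in this assay compound 2 gives 25.3%. Compound 3 `Nc1ccccc1NC(=O)c1ccc(CSC(=S)N2CCN(c3cccnc3)CC2)cc1` differs from compound 2 only in the group on that ring nitrogen, and in this assay compound 3 gives 27.6%. Compound 1 thus stands highest of the three, well clear of both others.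

Compound 4 `CN(C(=S)SCc1ccc(C(=O)Nc2ccccc2N)cc1)c1cccnc1` has not been measured. It differs from compound 1 in one place: methyl(pyridin-3-yl)amino in place of ethyl((pyridin-4-yl)methyl)amino on a thiocarbonyl carbon. Among the compounds with values here, the only measured single step, a number 2.3 percentage points higher from compound 2 to compound 3 (within the scatter), exchanges one aryl for another on an amine nitrogen in a ring and does not touch the change made here, so no measured step bears on it directly. What the values show is that compound 2, at 25.3%, and compound 3, at 27.6%, both with the amine nitrogen in a ring, sit far under compound 1, whereas compound 4 keeps an amine not held in a ring yet places the pyridin-3-yl directly on that nitrogen as compounds 2 and 3 do. A drop of middling size, a number 26.6 percentage points lower from compound 1 to compound 4 (beyond the scatter), is therefore expected, with wide uncertainty. Compound 4 is estimated to give 45% in this assay, with a range from 20% to 70%.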

Compound 4, a percentage reported as inhibition, at one concentration (the size of the read-out at that concentration, not a potency): 46.1%
For compound 4 the middle estimate is 1.1 percentage points below the measured one; the measured number falls inside the stated range.
By their numbers in this assay, from the lowest: compounds 2 and 3 (each within the scatter of the next); then compound 4; then compound 1.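

The step of a number 25.5 percentage points lower from compound 1 to compound 4 (beyond the scatter) in this assay shows that the group on the thiocarbonyl carbon matters even when the amine nitrogen stays outside a ring, whereas the earlier step of a number 2.3 percentage points higher from compound 2 to compound 3 (within the scatter) changed only the aryl group on a ring nitrogen. This exchange bundles several changes into one: ethyl becomes methyl, the pyridine ring loses its methyl link and sits directly on the amine nitrogen, the ring is attached through a different position, and the group shrinks from 10 heavy atoms to 8, so the drop cannot be assigned to any one of these changes. No measurement shown here gives a reason for the drop.

On these data alone, what remains open is which of these changes carries the effect, and groups that alter one feature at a time would separate them, such as methyl((pyridin-4-yl)methyl)amino for the alkyl chain alone or ethyl((pyridin-3-yl)methyl)amino for the ring attachment alone. Also open, as far as these compounds go, is how a longer chain such as propyl on the amine nitrogen, or a phenyl ring in place of the pyridine, would read in this assay.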